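Replacing ethoxy with a boron group: an expected step

The compounds below may be only part of what the source reports. "The series", "measured", "known", "first", "only" and "open" are said of these compounds alone.

In a functional assay on HeLa cells (Homo sapiens) for antiproliferative activity, read by CCK-8 assay, with a stated time of 72 h (on this read-out lower numbers stand for stronger inhibition and higher numbers for weaker inhibition), compound 2 (`CCOc1ccc(-c2cncnc2-c2cc(OC)c(OC)c(OC)c2)cc1`) gives 250 nM and so stands in the middle of three numbers. Compound 1 (`CCOC(=O)Oc1cc(-c2cncnc2-c2cc(OC)c(OC)c(OC)c2)ccc1OC`) reads higher at 650 nM and compound 3 (`CCOc1ccc(-c2cncnc2-c2cc(OC)c(OC)c(OC)c2)cc1Cl`) reads lower at 90 nM with both gaps beyond the usual scatter.

Compound 4 (`COc1cc(-c2ncncc2-c2ccc(B(O)O)cc2)cc(OC)c1OC`) has not been measured yet. It loses the ethoxy group of compound 2 on an aromatic carbon, para to a large group, and carries a group of boron and oxygen there instead (a group of 3 heavy atoms (1 boron, 2 oxygen; no ring) in place of a group of 3 heavy atoms (2 carbon, 1 oxygen; no ring), on an aromatic carbon).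

Among the compounds with values here, only one measured step bears on this: a 2.8-fold lower number from compound 2 to compound 3 (0.44 log units; beyond the scatter) for chloro in place of hydrogen on an aromatic carbon. It shows that one small change on this ring can move the number modestly. Yet it is a different change at a different place, and no measured compound tests this swap. Within the data shown here, the entering group has hydrogen-bond donors, and none of the measured compounds has any. A step of similar size in this assay is expected, toward a higher number, though that direction is a judgement resting on little data. The estimate amounts to a 2.4-fold higher number from compound 2 to compound 4 (0.38 log units; beyond the scatter) at its middle value. Compound 4 is estimated at 600 nM with an expected range from 120 nM to 3000 nM for now.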

Compound 4, half-maximal inhibitory concentration: 4000 nM
Compound 4: middle estimate off by 6.7-fold (0.82 log units), on the low side, and the stated range ends below it.
By their numbers in this assay, from the lowest: compound 3; then compound 2; then compound 1; then compound 4.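

In this assay, this swap on an aromatic carbon, para to a large group, gives a large step (a 16-fold higher number from compound 2 to compound 4 (1.20 log units; beyond the scatter)), so this position does not accept every small group equally. Within the data shown here, the only earlier step on this ring (a 2.8-fold lower number from compound 2 to compound 3 (0.44 log units; beyond the scatter)) was modest, went toward a lower number and involved a different change at a different place, so it gave no sign that a single swap here could move the number this far. Ethoxy and the entering group each have 3 heavy atoms, so that count alone does not settle the number, and the clearest computed differences are the 2 hydrogen-bond donors and the boron atom, although nothing here explains the rise.

Compound 4 alone cannot separate the effect of the boron atom from that of the hydrogen-bond donors, and a carboxylic acid or an amine on the same aromatic carbon would help to pull them apart. Also open, from the compounds shown here alone, is whether a longer chain, such as propoxy, would keep a number close to that of compound 2, and whether adding chloro to compound 4 would lower its number as it did for compound 2.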